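A few compounds are considered here, and "the series" means these few. Any claim that something is new, unique, unknown or untested is made for them only; others in the source may bear on it.

Compound 1 `CCOc1ccc(-c2cc(=O)c3c(o2)C(CC)(CC)C(=O)C(CC)=C3O)cc1`: 7.54 uM
Compound 2 `CCC1=C(O)c2c(oc(-c3ccc(C)c(C)c3)cc2=O)C(CC)(CC)C1=O`: 0.71 uM
Compound 3 `CCC1=C(O)c2c(oc(-c3cc(C)c(C)cc3C)cc2=O)C(CC)(CC)C1=O`: 4.37 uM

In a functional assay on KBVIN cells (Homo sapiens) for antiproliferative activity, read by sulforhodamine B assay, with a stated time of 3 days (on this read-out lower numbers stand for an effect already at smaller amounts and higher numbers for an effect only at larger amounts of compound), compound 3 stands second highest of the three numbers, close to compound 1 and well apart from compound 2. Compound 4 `CCC1=C(O)c2c(oc(-c3cc(C)cc(C)c3)cc2=O)C(CC)(CC)C1=O` is still to be measured; it differs from compound 3 by 3,5-dimethylphenyl in place of 2,4,5-trimethylphenyl on an aromatic carbon. The relevant step is a 6.2-fold higher number from compound 2 to compound 3 (0.79 log units; beyond the scatter), in which one extra methyl on the aromatic ring raised the number. Among the measured compounds shown here, compound 4 carries two methyls, as compound 2 does, but in a different arrangement, and no step between compound 2 and compound 4 has been measured. A modest step downward is therefore expected, a 2.2-fold lower number from compound 3 to compound 4 (0.34 log units; beyond the scatter). Compound 4 is estimated at 2 uM, with a range from 0.7 uM to 6 uM.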

Compound 4, concentration for half-maximal effect: 0.45 uM
Compound 4: middle estimate off by 4.4-fold (0.65 log units), on the high side, and the stated range ends above it.
By their numbers in this assay, from the lowest: compounds 4 and 2 (each within the scatter of the next); then compounds 3 and 1 (each within the scatter of the next).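

In this assay, shifting a methyl on this aromatic group from the 3,4-dimethylphenyl to the 3,5-dimethylphenyl arrangement gives no readable difference (with a 1.6-fold lower number from compound 2 to compound 4 (0.20 log units; within the scatter)). Both dimethylphenyl groups separate from the others, as 3,5-dimethylphenyl in place of 2,4,5-trimethylphenyl gives a 9.7-fold lower number from compound 3 to compound 4 (0.99 log units; beyond the scatter), and in place of 4-ethoxyphenyl gives a 17-fold lower number from compound 1 to compound 4 (1.22 log units; beyond the scatter). No measurement shown here accounts for these differences. Still open is whether dimethylphenyl is special among these four compounds or whether other groups on the ring, such as an amine or a carboxylic acid, would give similarly low numbers.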